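Replacing methoxy with trifluoromethyl in compound 3

The compounds below may be only part of what the source reports. "The series", "measured", "known", "first", "only" and "open" are said of these compounds alone.

Compound 1 `[O-]/[N+](=C\c1cn(-c2ccccc2)nn1)Cc1ccccc1` gives 8000 nM
Compound 2 `[O-]/[N+](=C\c1cn(-c2ccc(F)cc2)nn1)Cc1ccccc1` gives 9700 nM
Compound 3 `COc1ccc(-n2cc(/C=[N+](\[O-])Cc3ccccc3)nn2)cc1` gives 17300 nM

In a functional assay on THP-1 cells (Homo sapiens) for inhibition, read by ELISA, with stated times of 2 h and 48 h (on this read-out lower numbers stand for stronger inhibition and higher numbers for weaker inhibition), compound 3 gives 17300 nM, standing against its neighbours with a 2.2-fold higher number from compound 1 to compound 3 (0.33 log units; beyond the scatter) and a 1.8-fold higher number from compound 2 to compound 3 (0.25 log units; within the scatter). Compound 4 `[O-]/[N+](=C\c1cn(-c2ccc(C(F)(F)F)cc2)nn1)Cc1ccccc1` differs from it by one change, trifluoromethyl in place of methoxy on an aromatic carbon. Within the data shown here, no trifluoromethyl compound has been measured, so the guide is indirect. Fluoro in compound 2 left the number close to that of compound 1, with a 1.2-fold higher number from compound 1 to compound 2 (0.08 log units; within the scatter), and only methoxy in compound 3 went beyond the scatter. Losing methoxy is therefore expected to give a small change in this assay toward a lower number, a 1.6-fold lower number from compound 3 to compound 4 (0.22 log units; within the scatter). For compound 4 the estimate is 10500 nM, with an expected range of 5500 nM to 20000 nM.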

Compound 4, half-maximal inhibitory concentration: 15400 nM
Compound 4: the middle estimate sits 1.5-fold (0.17 log units) below what was measured; the measured number falls inside the stated range.
By their numbers in this assay, from the lowest: compounds 1, 2, 4 and 3 (each within the scatter of the next, the first and the last beyond it).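

In this assay, trifluoromethyl on this aromatic carbon, para to a large group, gives a number that cannot be told apart from that with methoxy (a 1.1-fold lower number from compound 3 to compound 4 (0.05 log units; within the scatter)), with fluoro (a 1.6-fold higher number from compound 2 to compound 4 (0.20 log units; within the scatter)) or with hydrogen (a 1.9-fold higher number from compound 1 to compound 4 (0.28 log units; within the scatter)). Among these compounds, the position has now taken three different groups, and only the step from hydrogen to methoxy lies beyond the scatter. Nothing available explains this result.

On these data alone, whether an amine or a carboxylic acid at this carbon would give a clearer separation remains open. So does whether changes elsewhere on the shared core would do more.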